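The source may hold more compounds than are shown below. What is called first, only, known or untested is meant among the compounds shown, and "the series" means these compounds.

Measured in a functional assay on HEK293 cells for agonist activity at Bile acid receptor (Homo sapiens), read by a luciferase reporter; a higher number here means a larger maximal response, a lower number a smaller maximal response:
compound 1 `CN(Cc1cccc(C(=O)O)c1)c1ccc(OCc2c(-c3c(Cl)cccc3Cl)noc2C2CC2)nc1C(F)(F)F`, 43%
compound 2 `CN(Cc1ccc(C(=O)O)cc1)c1ccc(OCc2c(-c3c(Cl)cccc3Cl)noc2C2CC2)nc1C(F)(F)F`, 60%
compound 3 `CC(C)c1onc(-c2c(Cl)cccc2Cl)c1COc1cnc(N(C)Cc2ccc(C(=O)O)cc2)c(Cl)c1`, 51%

Compound 2 and compound 1 share one core and differ by 3-carboxyphenyl in place of 4-carboxyphenyl on a saturated chain carbon bound to a nitrogen on an aromatic ring; this change gave a number 17 percentage points lower from compound 2 to compound 1 (beyond the scatter). Compound 3 sits on a different core; the difference between the core of compound 2 and the core of compound 3 is not broken down here. Compound 3 and compound 1 lie within the scatter of each other in this assay, as do compound 3 and compound 2, so no order among them is claimed.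

Compound 4 `CC(C)c1onc(-c2c(Cl)cccc2Cl)c1COc1cnc(N(C)Cc2cccc(C(=O)O)c2)c(Cl)c1` is not yet measured. It differs from compound 3 by 3-carboxyphenyl in place of 4-carboxyphenyl on a saturated chain carbon bound to a nitrogen on an aromatic ring, the same change as between compound 2 and compound 1. Going by the values given here, a step of a number 15 percentage points lower from compound 3 to compound 4 (beyond the scatter) in this assay is expected for compound 4, resting on the single earlier instance, a number 17 percentage points lower from compound 2 to compound 1 (beyond the scatter). Compound 4 is estimated at 36%, expected between 22% and 50%. Among the compounds with values here, only one precedent exists, on another core, so the transfer is uncertain.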

Compound 4, largest response reached (reported as efficacy), in percent of the reference or control that the assay uses: 54%
Compound 4: middle estimate off by 18 percentage points, on the low side, outside the stated range (above it).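

In this assay, 3-carboxyphenyl in place of 4-carboxyphenyl gave a number 3 percentage points higher from compound 3 to compound 4 (within the scatter), so the drop seen on the core of compound 2 did not carry over to the core of compound 3: the same change on two cores in this assay, a number 17 percentage points lower (beyond the scatter) from compound 2 to compound 1 and a number 3 percentage points higher (within the scatter) from compound 3 to compound 4, 20 percentage points apart, beyond the scatter of two such steps
This shows that, for these two pairs, the outcome of the change depends on the core, and a step measured on one core is not a safe guide to the other. It does not show which difference between the two cores matters, as they are not broken down into single changes, and one pair per core gives no rule for any further core.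

The compounds shown leave open how an amide or a tetrazole in place of the carboxylic acid would behave in this assay. On these data alone, a longer chain carrying the carboxylic acid also remains open, on either core.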